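Fluoro for Chloro: What Compound 3 Should Show

The compounds below may be only part of what the source reports. "The series", "measured", "known", "first", "only" and "open" are said of these compounds alone.

Compound 1, `COc1cc(OC)c(C(=O)/C=C/c2ccc(Cl)cc2)c(OC)c1`, gives 0.2% in a functional assay on PC-3 cells (Homo sapiens), read by fluorescence and BrdU incorporation, with a stated time of 48 h, tested at 25 uM; a higher number here means a weaker effect of the compound at the concentration tested, a lower number a stronger effect.
Compound 2, `COc1cccc(/C=C/C(=O)c2c(O)cc(OC)cc2OC)c1`, gives 9.4% in this assay.

Of the compounds shown here, two have been measured so far. Compound 1 stands alongside compound 2: the two numbers lie within the usual scatter of each other, so neither can be set apart from the other in this assay.

The unmeasured compound 3, `COc1cc(OC)c(C(=O)/C=C/c2ccc(F)cc2)c(OC)c1`, differs from compound 1 in a single place: fluoro in place of chloro on an aromatic carbon. Among the compounds with values here, no step between two measured compounds of this set exists to calibrate such a swap, so the expectation rests on the change itself and on the number of compound 1.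

A step of this kind is expected to stay within the scatter, in no clear direction, so the change from compound 1 is estimated at a number 2.8 percentage points higher from compound 1 to compound 3 (within the scatter). Compound 3 is therefore expected to give about 3%, within a range from 0% to 20%.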

Compound 3, a percentage reported as activity, at one concentration (the size of the read-out at that concentration, not a potency): 0.4%
Compound 3: middle estimate off by 2.6 percentage points, on the high side, within the range that was stated.
By their numbers in this assay, from the lowest: compounds 1, 3 and 2 (each within the scatter of the next).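

In this assay, within the data shown here, replacing the 4-chlorophenyl with a 4-fluorophenyl gives a number 0.2 percentage points higher from compound 1 to compound 3 (within the scatter), the first step in this set that isolates a change at one place. At this position, para to a large group, chloro and fluoro cannot be told apart by this read-out, so the effect seen for compound 1 does not depend on chlorine in particular. No measurement shown here bears on why the two halogens read alike.

From the compounds shown here alone, whether the position accepts a group other than a halogen, such as an amine or a carboxylic acid, remains open. Since the read-out comes from a single concentration, it also leaves open whether compound 1 and compound 3 would differ in potency.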